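A Methyl Step from Compound 2 to Compound 3

The source may report more compounds than this note shows. Statements on the series, on what has been measured and on what is new or still open speak of the compounds shown alone.

In a functional assay on QGY-7703 cells (Homo sapiens) for cytotoxicity, read by MTT assay, with a stated time of 24 h (a lower number here means a stronger inhibitor, a higher number a weaker inhibitor), compound 1 `Cc1ccc(S(=O)(=O)N2C/C(=C\c3cccnc3)C(=O)/C(=C/c3ccccc3C(F)(F)F)C2)cc1` gives 6170 nM and compound 2 `O=C1/C(=C/c2ccncc2)CN(S(=O)(=O)c2ccccc2)C/C1=C\c1ccccc1C(F)(F)F` gives 6210 nM so the two values lie within the scatter of each other. Compound 3 `Cc1ccc(S(=O)(=O)N2C/C(=C\c3ccncc3)C(=O)/C(=C/c3ccccc3C(F)(F)F)C2)cc1` differs from compound 2 methyl in place of hydrogen on an aromatic carbon with methyl in place of hydrogen on an aromatic carbon, para to a large group, which turns phenylsulfonyl to (4-methylphenyl)sulfonyl. Going by the values given here, no measured pair shows this change on its own, so there is no direct precedent for its size. The expectation therefore starts from compound 2 at 6210 nM and foresees no shift beyond the scatter in either direction. The expected change is a 1.0-fold lower number from compound 2 to compound 3 (0.01 log units; within the scatter) and no more than that. For compound 3 the expected value is 6000 nM with an estimated range from 2800 nM to 12000 nM in this assay once measured.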

Compound 3, half-maximal inhibitory concentration: 5090 nM
Compound 3: middle estimate off by 1.2-fold (0.07 log units), on the high side; measured number inside the range.
By their numbers in this assay, from the lowest: compounds 3, 1 and 2 (each within the scatter of the next).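

In this assay, going by these compounds alone, methyl in place of hydrogen on an aromatic carbon, para to a large group, gives a 1.2-fold lower number from compound 2 to compound 3 (0.09 log units; within the scatter) and so offers a first reading of this change: phenylsulfonyl and (4-methylphenyl)sulfonyl are not separated here. Pyridin-4-yl in place of pyridin-3-yl, with the (4-methylphenyl)sulfonyl kept, gives a 1.2-fold lower number from compound 1 to compound 3 (0.08 log units; within the scatter) and so the second single change also stays inside the scatter, leaving the three compounds unresolved from one another. Nothing further is available to account for either small step.

The compounds shown leave open whether a different group on that aromatic carbon, such as a methoxy group, an amine or a carboxylic acid, would move the number beyond the scatter. They also leave open whether a longer chain there would do so.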